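From carboxy to methoxycarbonyl: a single methyl change

A few compounds are considered here, and "the series" means these few. Any claim that something is new, unique, unknown or untested is made for them only; others in the source may bear on it.

Compound 1 `COC(=O)c1cc(-n2cc(-c3ccc(OC)cc3)nn2)ccc1O` gives 6% in a functional assay on HCT-116 cells (Homo sapiens) for inhibition, read by MTT assay, with a stated time of 2 days, tested at 10 uM; a lower number here means less inhibition, a higher number more inhibition at the concentration tested (going by the name of the read-out). Among the measured compounds shown here, compound 2 `COc1ccccc1-c1cn(-c2ccc(O)c(C(=O)O)c2)nn1` gives 4% in this assay, the lowest of the two numbers so far, with compound 1 only two points higher, a gap within the scatter. Compound 3 `COC(=O)c1cc(-n2cc(-c3ccccc3OC)nn2)ccc1O` differs from compound 2 by methyl in place of hydrogen on an oxygen next to a carbonyl group. Since compound 1, which already carries the methoxycarbonyl group, sits at 6%, the step of a number 2 percentage points higher from compound 2 to compound 3 (within the scatter) is expected to be none beyond the scatter. Compound 3 is therefore estimated at 6%, with a range from -5% to 18%.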

Compound 3, a percentage reported as inhibition, at one concentration (the size of the read-out at that concentration, not a potency): 8%
Beside the measured number, compound 3's estimate is 2 percentage points below it; the measured number falls inside the stated range.
By their numbers in this assay, from the lowest: compounds 2, 1 and 3 (each within the scatter of the next).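

Methyl in place of hydrogen on an oxygen next to a carbonyl group gives a number 4 percentage points higher from compound 2 to compound 3 (within the scatter) in this assay, so carboxy and methoxycarbonyl cannot be told apart here. Likewise, 2-methoxyphenyl in place of 4-methoxyphenyl gives a number 2 percentage points higher from compound 1 to compound 3 (within the scatter), so that swap also shows no change beyond the scatter. Nothing available explains these small differences.

The compounds shown leave open whether any group at this position could raise the number well beyond the scatter. Going by these compounds, an amide or an amine in place of the methoxycarbonyl group, or a longer chain such as ethyl on that oxygen, remains untested here.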